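One Carbon More in the Chain: Compound 3 to Compound 4

The compounds below may be only part of what the source reports. "The series", "measured", "known", "first", "only" and "open" are said of these compounds alone.

Compound 1, `C#Cc1cccc(Nc2ncnc3cc(OCCCCn4ccnc4[N+](=O)[O-])c(OC)cc23)c1`, gives 590 nM in a functional assay on HT-29 cells (Homo sapiens) for inhibition, read by sulforhodamine B assay, with a stated time of 72 h; on this read-out lower numbers stand for stronger inhibition and higher numbers for weaker inhibition.
Compound 2, `C#Cc1cccc(Nc2ncnc3cc(OCCCCCn4ccnc4[N+](=O)[O-])c(OC)cc23)c1`, gives 280 nM in this assay.
Compound 3, `COc1cc2c(Nc3cccc(Br)c3)ncnc2cc1OCCCCCn1ccnc1[N+](=O)[O-]`, gives 2540 nM in this assay.

Compound 2 differs from compound 1 by (2-nitro-1H-imidazol-1-yl)methyl in place of 2-nitro-1H-imidazol-1-yl on a saturated chain carbon, four bonds along the chain from an oxygen on an aromatic ring. That change gave a 2.1-fold lower number from compound 1 to compound 2 (0.32 log units; beyond the scatter). Compound 3 differs from compound 2 by bromo in place of ethynyl on an aromatic carbon, a change that gave a 9.1-fold higher number from compound 2 to compound 3 (0.96 log units; beyond the scatter), leaving compound 3 with the highest number of the three. How the core of compound 3 differs from that of compound 1 is not broken down here.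

Compound 4, `COc1cc2c(Nc3cccc(Br)c3)ncnc2cc1OCCCCCCn1ccnc1[N+](=O)[O-]`, is not yet measured. It differs from compound 3 by (2-nitro-1H-imidazol-1-yl)methyl in place of 2-nitro-1H-imidazol-1-yl on a saturated chain carbon, five bonds along the chain from an oxygen on an aromatic ring. The change in compound 4 sits five bonds along the chain from the oxygen, while in compound 2 it sits four bonds along; it is therefore the same kind of change, not the same one.

For compound 4 a step of about a 2.1-fold lower number from compound 3 to compound 4 (0.33 log units; beyond the scatter) is expected in this assay, resting on the earlier step in compound 2, which was a 2.1-fold lower number from compound 1 to compound 2 (0.32 log units; beyond the scatter). Going by the values given here, with only one such precedent, the estimate for compound 4 is 1200 nM, expected to lie between 500 nM and 2800 nM.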

Compound 4, half-maximal inhibitory concentration: 4300 nM
Estimate against measurement, compound 4: 3.6-fold (0.55 log units) below, and the stated range ends below it.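

On the core of compound 3, the added chain carbon gave a 1.7-fold higher number from compound 3 to compound 4 (0.23 log units; within the scatter) in this assay, so this pair shows no real difference between the two chain lengths. Going by these compounds alone, the same kind of change therefore did not carry over from one core to the other, and a gain on the ethynyl core was no guide to the result on the bromo core: the same change on two cores in this assay, a 2.1-fold lower number (0.32 log units; beyond the scatter) from compound 1 to compound 2 and a 1.7-fold higher number (0.23 log units; within the scatter) from compound 3 to compound 4, 3.6-fold (0.55 log units) apart, beyond the scatter of two such steps This does not show why the two steps part, nor that the core alone decides the outcome, since each core offers only one step and the change sits four bonds along the chain in one and five bonds along in the other.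

The compounds shown leave open how the ethynyl core would respond at the chain length of compound 4, a comparison that would help separate the effect of the core from that of the place on the chain. Also open, as far as these compounds go, is whether a longer chain, or an amine in place of 2-nitro-1H-imidazol-1-yl, would follow either step.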